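Methyl in place of methoxy: expectation for compound 4

The source may report more compounds than this note shows. Statements on the series, on what has been measured and on what is new or still open speak of the compounds shown alone.

In a functional assay on HeLa cells (Homo sapiens) for antiproliferative activity, with a stated time of 5 days (on this read-out lower numbers stand for stronger inhibition and higher numbers for weaker inhibition), compound 3 (`COc1ccc(-n2nc(-c3ccc4ccccc4c3)nc2N2C(=O)C(C)OC23C=CC(=O)C=C3)cc1`) gives 140 nM. Compound 2 (`CC1OC2(C=CC(=O)C=C2)N(c2nc(-c3ccc4ccccc4c3)nn2-c2ccccc2)C1=O`) gives 120 nM, and compound 1 (`CC1OC2(C=CC(=O)C=C2)N(c2nc(-c3ccc4ccccc4c3)nn2-c2ccc3ccccc3c2)C1=O`) gives 300 nM. Compound 3 cannot be told apart from compound 2, and both stand lower than compound 1.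

Compound 4 (`Cc1ccc(-n2nc(-c3ccc4ccccc4c3)nc2N2C(=O)C(C)OC23C=CC(=O)C=C3)cc1`) has methyl in place of methoxy on an aromatic carbon, para to a large group: methyl in place of methoxy on an aromatic carbon. Within the data shown here, no measured compound carries methyl, so the evidence is indirect. The nearest step is methoxy in place of hydrogen at that same carbon, a 1.2-fold higher number from compound 2 to compound 3 (0.07 log units; within the scatter). The replacements of naphthalen-2-yl, a 2.5-fold lower number from compound 1 to compound 2 (0.40 log units; beyond the scatter) and a 2.1-fold lower number from compound 1 to compound 3 (0.33 log units; beyond the scatter), were modest and involve a much larger change, so they bear on this step only weakly. In this assay, no step beyond the scatter is therefore expected, in either direction. The estimated step is a 1.1-fold lower number from compound 3 to compound 4 (0.03 log units; within the scatter). Compound 4 is expected at 130 nM, with an estimated range of 70 nM to 240 nM.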

Compound 4, half-maximal inhibitory concentration: 530 nM
Compound 4: middle estimate off by 4.1-fold (0.61 log units), on the low side; the whole stated range lies below it.
By their numbers in this assay, from the lowest: compounds 2 and 3 (each within the scatter of the next); then compounds 1 and 4 (each within the scatter of the next).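

In this assay this position, on an aromatic carbon para to a large group, turns out to discriminate between small groups: methyl gives a step beyond the scatter against both methoxy (a 3.8-fold higher number from compound 3 to compound 4 (0.58 log units; beyond the scatter)) and hydrogen (a 4.4-fold higher number from compound 2 to compound 4 (0.65 log units; beyond the scatter)), whereas hydrogen and methoxy could not be told apart. With methyl in place, the replacement of naphthalen-2-yl no longer gives a step beyond the scatter (a 1.8-fold higher number from compound 1 to compound 4 (0.25 log units; within the scatter)), so the gain seen with phenyl and 4-methoxyphenyl does not extend to 4-methylphenyl. Nothing available explains why methyl departs from hydrogen and methoxy here.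

From the compounds shown here alone, whether this loss is particular to methyl remains open, and an ethyl, a hydroxyl, an amine or a chlorine at this carbon would test that. Also open, going by these compounds, is whether the same order holds when the remaining naphthalen-2-yl group is changed.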